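This account rests on a few compounds, and the source may have more. Where it says the series, first, only, none or still open, it means among the compounds named here.

Measured so far: compound 1 `CCCCCCCCS(=O)(=O)Nc1ccc(-c2ccccc2F)cc1C(=O)O` and compound 2 `CCCCCCCCS(=O)(=O)Nc1ccc(C(=O)c2ccccc2OC)cc1C(=O)O`.

In an assay on mitochondria (strain BALB/c) for inhibition of glycerol-3-phosphate acyltransferase 1, mitochondrial (Mus musculus), read by scintillation counting, with a stated time of 10 min (on this read-out lower numbers stand for stronger inhibition and higher numbers for weaker inhibition), compound 1 gives 34600 nM, and compound 2 gives 59200 nM. For the measured compounds named here, compound 2 stands alongside compound 1, the only other number, since the step of a 1.7-fold higher number from compound 1 to compound 2 (0.23 log units; within the scatter) lies within the scatter. Compound 3 `CCCCCCCCS(=O)(=O)Nc1ccc(C(=O)c2ccc(OC)cc2)cc1C(=O)O` differs from compound 2 by 4-methoxyphenyl in place of 2-methoxyphenyl on a carbonyl carbon. Going by the values given here, no measured step turns 2-methoxyphenyl into 4-methoxyphenyl; the one recorded step swapped 2-fluorophenyl for (2-methoxyphenyl)carbonyl and stayed small. For compound 3 a step no larger than the scatter is therefore expected, a 1.2-fold lower number from compound 2 to compound 3 (0.07 log units; within the scatter). Compound 3 is estimated at 50000 nM, ranging from 18000 nM to 140000 nM.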

Compound 3, half-maximal inhibitory concentration: 44300 nM
Beside the measured number, compound 3's estimate is 1.1-fold (0.05 log units) above it; the range from low to high includes it.
By their numbers in this assay, from the lowest: compounds 1, 3 and 2 (each within the scatter of the next).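

In this assay, putting 4-methoxyphenyl in place of 2-methoxyphenyl on the carbonyl carbon gives only a small step (a 1.3-fold lower number from compound 2 to compound 3 (0.13 log units; within the scatter)), so this change, the first tested on that carbon, cannot be told apart from assay noise. Putting (4-methoxyphenyl)carbonyl in place of 2-fluorophenyl on the aromatic carbon is just as small (a 1.3-fold higher number from compound 1 to compound 3 (0.11 log units; within the scatter)), so all three compounds remain within the scatter of one another. No available evidence bears on this result.

As far as these compounds go, whether a 4-aminophenyl or 4-cyanophenyl group on that same carbonyl carbon would give a step beyond the scatter remains open.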